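Fluoro on the benzyl ring: compound 3 to compound 4

The source may hold more compounds than are shown below. What is called first, only, known or untested is meant among the compounds shown, and "the series" means these compounds.

Measured so far in a functional assay on the whole organism (artery, strain albino) with Rattus norvegicus as the target, with a stated time of 15 min, at a dose of 10 mg/kg by the oral route; a higher number here means more inhibition at the dose given (going by the name of the read-out), a lower number less inhibition:
compound 1 `CC1=C(C(=O)Nc2ccc(F)cc2)C(c2ccc([N+](=O)[O-])cc2)N=C(SCc2ccc(Cl)cc2)N1`, 3.6%
compound 2 `CC1=C(C(=O)Nc2ccc(Br)cc2)C(c2ccc(Cl)cc2Cl)N=C(SCc2ccccc2)N1`, 1.5%
compound 3 `COc1ccc(C2N=C(SCc3ccccc3)NC(C)=C2C(=O)Nc2ccc(Br)cc2)cc1`, 1%

On the numbers shown, compound 3 sits at the bottom of the three, yet no two of these numbers are separated by more than the usual scatter: compound 2 is nearest, compound 1 furthest, and both gaps are within it. Among the compounds with values here, the one step recorded between compounds that differ in a single place, a number 0.5 percentage points lower from compound 2 to compound 3 (within the scatter), also lies within the scatter.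

Compound 4 `COc1ccc(C2N=C(SCc3ccc(F)cc3)NC(C)=C2C(=O)Nc2ccc(Br)cc2)cc1` differs from compound 3 in one place: fluoro in place of hydrogen on an aromatic carbon. Within the data shown here, none of the measured steps touches this ring, so no step bears directly on the change. Compound 1 carries a halogen on the corresponding ring, alongside other differences, and in this assay compound 1 gives 3.6%, which is no further from compound 3 than the scatter. All three measured numbers are small and alike, and nothing in them suggests that a fluoro on this ring would move the read-out beyond the scatter.

For compound 4 the value in this assay is therefore estimated at 2%, with a range from 0% to 8%. The expected step is a number 1 percentage points higher from compound 3 to compound 4 (within the scatter), nothing beyond the scatter.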

Compound 4, a percentage reported as inhibition, in the whole organism at one dose (the size of the read-out at that dose, not a potency): 3.6%
Estimate against measurement, compound 4: 1.6 percentage points below, within the range that was stated.
By their numbers in this assay, from the lowest: compounds 3, 2, 1 and 4 (each within the scatter of the next).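

In this assay, replacing hydrogen with fluoro on an aromatic carbon of the benzyl ring gives a number 2.6 percentage points higher from compound 3 to compound 4 (within the scatter). This is the first step among the compounds shown that isolates a change on this ring, since the earlier step changed only the aryl group on the saturated ring carbon, so the change from benzyl to 4-fluorobenzyl can now be read without other differences mixed in. Read on its own, the step shows that this single fluoro, with the rest of compound 3 kept in place, leaves the read-out within the usual scatter at this dose, and no measurement shown offers an explanation for this result.

The compounds shown leave open whether a different group at the same place on the ring, such as an amine or a carboxylic acid, would give a step beyond the scatter. They also leave open whether a longer chain in place of the benzyl group would move the read-out any further than fluoro does here.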